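A few compounds are considered here, and "the series" means these few. Any claim that something is new, unique, unknown or untested is made for them only; others in the source may bear on it.

Of the compounds shown here, three built on the same core have been measured in a functional assay (FL5.12 cells, Mus musculus) with Apoptosis regulator Bcl-2 (Homo sapiens) as the target; on this read-out lower numbers stand for an effect already at smaller amounts and higher numbers for an effect only at larger amounts of compound. Compound 1 `COc1ccccc1C=C1CCN(c2ccc(C(=O)NS(=O)(=O)c3ccc(N[C@H](CCN(C)C)CSc4ccccc4)c([N+](=O)[O-])c3)cc2)CC1` gives 250 nM, and compound 2 `CN(C)CC[C@H](CSc1ccccc1)Nc1ccc(S(=O)(=O)NC(=O)c2ccc(N3CCC(=Cc4ccccn4)CC3)cc2)cc1[N+](=O)[O-]` gives 1380 nM; between them lies a 5.5-fold higher number from compound 1 to compound 2 (0.74 log units; beyond the scatter). Compound 3 `CN(C)CC[C@H](CSc1ccccc1)Nc1ccc(S(=O)(=O)NC(=O)c2ccc(N3CCN(C(=O)Nc4ccccc4)CC3)cc2)cc1[N+](=O)[O-]` reaches only a limit of the assay, > 50000 nM, so no number is known for compound 3 and it sits at the limit (the limit of > 50000 nM in this assay, at which 1 of the 3 values shown sits). Compound 4 `CN(C)CC[C@H](CSc1ccccc1)Nc1ccc(S(=O)(=O)NC(=O)c2ccc(N3CCN(Cc4ccccc4)CC3)cc2)cc1[N+](=O)[O-]` differs from compound 3 by benzyl in place of phenylcarbamoyl on an amine nitrogen in a ring. Within the data shown here, no measured step covers this change, since the step from compound 1 to compound 2 touches another part of the molecule. Compound 4 is therefore expected to give a number rather than a limit, estimated at 3000 nM within 500 nM to 30000 nM, an expected step of an at least 16-fold lower number from compound 3 to compound 4 (1.22 log units; beyond the scatter).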

Compound 4, half-maximal effective concentration: 1700 nM
Compound 4: middle estimate off by 1.8-fold (0.25 log units), on the high side, within the range that was stated.
By their numbers in this assay, from the lowest: compound 1; then compounds 2 and 4 (each within the scatter of the next). At a limit, above all of these: compound 3.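

Among these compounds, at the amine nitrogen in the ring, the only earlier compound with a substituent there, compound 3, gave no number, so compound 4 is the first to show that this position can carry a measurable compound. In this assay, benzyl in place of phenylcarbamoyl gives an at least 29-fold lower number from compound 3 to compound 4 (1.46 log units; beyond the scatter), a change that removes the hydrogen-bond donor and acceptor of phenylcarbamoyl. The true size of this step remains unknown because compound 3 stands at a limit of the assay: the limit of > 50000 nM in this assay, at which 1 of the 4 values shown sits.

Going by these compounds, whether phenethyl or acetyl on this nitrogen would give a number remains open. So does whether the carbonyl or the amide hydrogen of phenylcarbamoyl accounts for the step.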